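Shortening the Chain of a Weak Inhibitor

The compounds below may be only part of what the source reports. "The series", "measured", "known", "first", "only" and "open" are said of these compounds alone.

Compound 1 `CCCCCCCCOP(=O)(O)OCCSC(=S)N1CCCC1` was tested in a functional assay on PC-3 cells (Homo sapiens) for inhibition, read by MTT assay, with stated times of 18 h and 4 h; a higher number here means a weaker inhibitor, a lower number a stronger inhibitor. Compound 1 gives > 100000 nM, which is a limit of the assay and not a number. Compound 2 `CCCCCCCCOP(=O)(O)OCCSC(=S)N1CCN(C)CC1` gives > 100000 nM, also a limit. Compound 1 therefore stands at the limit of > 100000 nM in this assay, at which 2 of the 3 values shown sit. Only compound 3 `CCCCCCCCOP(=O)(O)OCCSC(=S)N1CCCCCC1` has a true number, at 56800 nM.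

Compound 4 `CCCOP(=O)(O)OCCSC(=S)N1CCCC1` differs from compound 1 in its chain: hydrogen in place of pentyl on a saturated chain carbon, three bonds along the chain from an oxygen on an unsaturated carbon. In words, this is hydrogen in place of pentyl on a saturated chain carbon, three bonds along the chain from an oxygen on an unsaturated carbon.

The measured steps all change the group on the thiocarbonyl carbon and leave the chain untouched. They are a step that the two limits leave unreadable from compound 1 to compound 2, then an at least 1.7-fold lower number from compound 1 to compound 3 (0.24 log units; that floor lies within the scatter), and finally an at least 1.7-fold lower number from compound 2 to compound 3 (0.24 log units; that floor lies within the scatter). None of them measures the chain change directly, and those with a readable floor do not clear the scatter.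

The expectation therefore rests on the starting point of compound 1, and no step beyond the scatter is foreseen. The expected step is a step that the limit leaves unreadable from compound 1 to compound 4, with no clear direction. Compound 4 is estimated at 150000 nM, with an expected range from 70000 nM to 300000 nM.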

Compound 4, half-maximal inhibitory concentration: > 100000 nM
Compound 4 was reported as a limit; the forecaster's own chance of this, stated with the estimate: 80%; the middle value is on the limit's open side.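

In this assay compound 4 gives > 100000 nM, which is a limit of the assay and not a number. Compound 1 is also reported only as a limit, so the step between compound 1 and compound 4 cannot be read, and compound 4 joins the values at that limit: the limit of > 100000 nM in this assay, at which 3 of the 4 values shown sit.

The compounds shown leave open whether hydrogen in place of pentyl changes inhibition at all.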